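The compounds below may be only part of what the source reports. "The series", "measured", "known", "first", "only" and "open" are said of these compounds alone.

Measured so far in a functional assay on MDA-MB-436 cells (Homo sapiens) for antiproliferative activity, read by MTT assay, with a stated time of 48 h; a lower number here means a stronger inhibitor, a higher number a weaker inhibitor:
compound 1 `C=CS(=O)(=O)N1CCN(c2ncnc3sc(-c4ccccc4)cc23)CC1` gives 21100 nM
compound 2 `C=CS(=O)(=O)N1CCN(c2ccn3ncc(-c4ccccc4)c3n2)CC1` gives 19500 nM
compound 3 `C=CS(=O)(=O)N1CCN(c2ncnc3ccc(-c4ccccc4)cc23)CC1` gives 23400 nM

Compound 1 lies within the usual scatter of both compound 2 and compound 3, so these three cannot be ranked. Compound 4 `C=CS(=O)(=O)N1CCN(c2ncnc3sc(-c4ccc(C(F)(F)F)cc4)cc23)CC1` has not yet been measured. It differs from compound 1 in one place (trifluoromethyl in place of hydrogen on an aromatic carbon): trifluoromethyl in place of hydrogen on an aromatic carbon, para to a large group, so phenyl becomes 4-(trifluoromethyl)phenyl. Among the compounds with values here, no measured pair shows such a change, so any forecast is loose. In this assay a small move toward a lower number is expected, perhaps none beyond the scatter. The expected change is a 1.8-fold lower number from compound 1 to compound 4 (0.25 log units; within the scatter) on this estimate. Compound 4 is estimated at 12000 nM (expected range 4000 nM to 30000 nM).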

Compound 4, half-maximal inhibitory concentration: 7080 nM
The estimate for compound 4 lay 1.7-fold (0.23 log units) above the measured number, within the range that was stated.
By their numbers in this assay, from the lowest: compound 4; then compounds 2, 1 and 3 (each within the scatter of the next).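

Compounds 1, 2 and 3 could not be ranked in this assay, so they showed no change that moved the number beyond the scatter. Here, trifluoromethyl in place of hydrogen, on an aromatic carbon para to a large group, gives a 3.0-fold lower number from compound 1 to compound 4 (0.47 log units; beyond the scatter) and so shows that this position on the phenyl of compound 1 can affect the read-out. Nothing measured here bears on why the number changes.

As far as these compounds go, whether fluorine, a methyl, an amine or a carboxylic acid at this place would shift the number stays open. So does whether trifluoromethyl would do the same on compound 2 or compound 3.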